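The compounds below may be only part of what the source reports. "The series", "measured", "known", "first", "only" and "open" are said of these compounds alone.

Measured compounds:
Compound 1 `COc1ccc(-c2cnc3nc(N)nc(N4CCN(C(=O)NCc5ccccc5)CC4)c3n2)cc1OC` gives 18 nM in a functional assay on cells (T-cell, Homo sapiens) for inhibition; a lower number here means a stronger inhibitor, a higher number a weaker inhibitor
Compound 2 `COc1ccc(-c2cnc3nc(N)nc(N4CCN(C(=O)c5ccccc5)CC4)c3n2)cc1OC` gives 400 nM
Compound 3 `COc1ccc(-c2cnc3nc(N)nc(N4CCN(C(=O)Nc5cccc(C)c5)CC4)c3n2)cc1OC` gives 7 nM

All three share one core and differ only in the group attached to the carbonyl on the piperazine. Compound 3 has the lowest number of the three: the step of a 2.6-fold lower number from compound 1 to compound 3 (0.41 log units; beyond the scatter) and the step of a 57-fold lower number from compound 2 to compound 3 (1.76 log units; beyond the scatter) both lie beyond the scatter, so compound 3 is the strongest inhibitor measured here. The largest change seen is a 22-fold higher number from compound 1 to compound 2 (1.35 log units; beyond the scatter), where a urea-type linkage gives way to a plain amide.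

Compound 4 `COc1ccc(-c2cnc3nc(N)nc(N4CCN(C(=O)Nc5ccccc5)CC4)c3n2)cc1OC` keeps the urea linkage of compound 3 and changes only the outer ring: hydrogen in place of methyl on an aromatic carbon. Among the measured compounds shown here, no measured step removes a methyl from such a ring, so nothing bears directly on this change; the nearest comparison, the step from a benzyl to a 3-methylphenyl group, was modest. The expectation is therefore a small step at most, likely a slight weakening, estimated as a 1.6-fold higher number from compound 3 to compound 4 (0.20 log units; within the scatter). Compound 4 is expected to give about 11 nM, within a range from 4 nM to 30 nM.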

Compound 4, half-maximal inhibitory concentration: 3.4 nM
Compound 4: the middle estimate sits 3.2-fold (0.51 log units) above what was measured; measured number outside the range, below it.
By their numbers in this assay, from the lowest: compound 4; then compound 3; then compound 1; then compound 2.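

In this assay, removing the methyl gives a 2.1-fold lower number from compound 3 to compound 4 (0.31 log units; beyond the scatter) and shows that this ring needs no methyl at the carbon in question for strong inhibition. Compound 4 also separates the effect of the benzyl group from that of the methyl: the plain comparison of phenyl with benzyl on the nitrogen gives a 5.3-fold lower number from compound 1 to compound 4 (0.72 log units; beyond the scatter) and favours phenyl. The matched change from phenyl to anilino on the carbonyl carbon gives a 120-fold lower number from compound 2 to compound 4 (2.07 log units; beyond the scatter) and is the largest step in the set, so the urea-type linkage with a plain phenyl ring now marks the strongest inhibitor shown.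

As far as these compounds go, it remains open whether a fluorine, a methoxy group or an amine on the same ring carbon would match the hydrogen. Nothing here explains why hydrogen outperforms methyl at this carbon.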